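This account rests on a few compounds, and the source may have more. Where it says the series, first, only, none or still open, it means among the compounds named here.

The study turns on three measured compounds that share one core, and a fourth that has not yet been run. Compound 1 `N#CC1=C(N)N(c2ccc(S(N)(=O)=O)cc2)C2=C(CCCC2)C1c1ccc(Cl)c(Cl)c1` carries a 3,4-dichlorophenyl group; in a functional assay on Ehrlich cells (Mus musculus) for cytotoxicity, read by trypan blue exclusion, with a stated time of 2 h (a lower number here means a stronger inhibitor, a higher number a weaker inhibitor), compound 1 gives 100 ug/mL. Compound 2 `COc1ccc2ccccc2c1C1C(C#N)=C(N)N(c2ccc(S(N)(=O)=O)cc2)C2=C1CCCC2` gives 100 ug/mL in this assay, so compound 1 stands level with compound 2 at the digits shown, the two lying within the scatter of each other. Compound 3 `COc1ccc(C2C(C#N)=C(N)N(c3ccc(S(N)(=O)=O)cc3)C3=C2CCCC3)c2ccccc12` shows no number in this assay but only a limit, > 100 ug/mL. That value is the limit of > 100 ug/mL in this assay, at which 1 of the 3 values shown sits. No two of the measured compounds differ in just one place, so no single step can be read off among them.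

Compound 4 `N#CC1=C(N)N(c2ccc(S(N)(=O)=O)cc2)C2=C(CCCC2)C1c1cccs1` is the unmeasured member. It differs from compound 1 by thiophen-2-yl in place of 3,4-dichlorophenyl on a saturated ring carbon. Every measured value in this assay sits at or beyond the same weak mark, and the change from compound 1 to compound 4 leaves the rest of the core untouched, so no step beyond the scatter is expected in either direction. Compound 4 is therefore estimated at 100 ug/mL in this assay, within 50 ug/mL to 200 ug/mL. The step this estimate means, no change at the digits printed from compound 1 to compound 4 (within the scatter), is expected to stay within the scatter.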

Compound 4, half-maximal inhibitory concentration: > 100 ug/mL
Compound 4: no number, only a limit; the forecaster's own chance of this, stated with the estimate: 40%; the middle value lies on the limit itself.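

In this assay, for the compounds shown here, the replacement of 3,4-dichlorophenyl by thiophen-2-yl on a saturated ring carbon gives the first step in this set that changes one place only: a number no lower from compound 1 to compound 4 (the limit leaves the size open). It shows that at this carbon, a five-membered aromatic ring with a sulfur atom in place of the chlorine-bearing six-membered ring brings no lower number, so this change opens no route to a stronger inhibitor in this assay. The reading for compound 4 is a limit and not a number, and it adds to the weak end of the series: the limit of > 100 ug/mL in this assay, at which 2 of the 4 values shown sit.

The size of the step remains unreadable, so the compounds shown leave open how far compound 4 lies from compound 1, and whether any group on this carbon can bring the number down at all. On these data alone, what a carboxylic acid, an amine or a longer chain would do at this carbon stays open, as does the effect of replacing the 4-sulfamoylphenyl group on the ring nitrogen.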